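This account rests on a few compounds, and the source may have more. Where it says the series, first, only, none or still open, it means among the compounds named here.

Compound 1 `C#CCOc1cccc(/C=C/C(=O)Nc2cc(C(=O)c3cc(OC)c(OC)c(OC)c3)ccc2OC)c1` stands with the highest of the two numbers in a functional assay on ME-180 cells (Homo sapiens) for cytotoxicity, read by MTT assay, with a stated time of 72 h (a higher number here means a weaker inhibitor, a lower number a stronger inhibitor), giving 15300 nM. Compound 2 `COc1ccc(C(=O)c2cc(OC)c(OC)c(OC)c2)cc1NC(=O)/C=C/c1ccc([N+](=O)[O-])cc1` gives 9300 nM, and the step of a 1.6-fold lower number from compound 1 to compound 2 (0.22 log units; within the scatter) stays within the scatter. Compound 3 `C#CCOc1cccc(/C=C/C(=O)Nc2cc(C(=O)c3cc(OC)c(OC)c(OC)c3)cc(OC)c2OC)c1` differs from compound 1 by methoxy in place of hydrogen on an aromatic carbon. Among the compounds with values here, the single measured step concerns the aryl group on the double-bonded chain, not the shared core, so no measured step bears directly on this change. Compound 3 is therefore expected to show no step beyond the scatter, a 1.3-fold lower number from compound 1 to compound 3 (0.11 log units; within the scatter). Compound 3 is estimated at 12000 nM, within a range from 4500 nM to 35000 nM.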

Compound 3, half-maximal inhibitory concentration: 8400 nM
For compound 3 the middle estimate is 1.4-fold (0.15 log units) above the measured one, within the range that was stated.
By their numbers in this assay, from the lowest: compounds 3, 2 and 1 (each within the scatter of the next).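

Methoxy in place of hydrogen on this aromatic carbon, ortho to a methoxy group, gives a 1.8-fold lower number from compound 1 to compound 3 (0.26 log units; within the scatter) in this assay. Within the data shown here, this is the first measured change on the shared core rather than on the aryl group of the double-bonded chain, and the added methoxy brings no step beyond the scatter. No evidence on the cause of this result is at hand.

As far as these compounds go, whether an amine or a longer alkoxy chain at this position would also stay within the scatter remains open. So does whether the added methoxy would give a similar step alongside the 4-nitrophenyl group of compound 2.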